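A few compounds are considered here, and "the series" means these few. Any claim that something is new, unique, unknown or untested is made for them only; others in the source may bear on it.

Measured compounds:
Compound 2, `Cc1occc1-c1nnc(SCC(=O)Nc2ccc(Cl)cc2)n1Cc1ccco1`, in a functional assay on CHO cells for antagonist activity at Orexin/Hypocretin receptor type 1 (Homo sapiens), read by FLIPR and calcium flux (a higher number here means a weaker inhibitor, a lower number a stronger inhibitor), gives 2000 nM.
Compound 1, `Cc1ccc(C)c(NC(=O)CSc2nnc(-c3ccoc3C)n2Cc2ccco2)c1`, in this assay gives only a limit, > 15800 nM.

Compound 2 therefore holds the only number shown in this assay; the other value is a limit, not a number. Compound 3, `Cc1occc1-c1nnc(SCC(=O)NN2CCc3ccccc32)n1Cc1ccco1`, has not yet been measured. It differs from compound 2 in one place: 2,3-dihydro-1H-indol-1-yl in place of 4-chlorophenyl on an amide-type nitrogen. Among the measured compounds shown here, the one measured step that bears on this position is an at least 7.9-fold lower number from compound 1 to compound 2 (0.89 log units; beyond the scatter). It shows that the group on the amide-type nitrogen moves the number strongly, and that not every group there yields a measurable number, since (the limit of > 15800 nM in this assay, at which 1 of the 2 values shown sits). For the measured compounds named here, the change to 2,3-dihydro-1H-indol-1-yl is a larger change than that step, and no measured compound carries a group of this kind on the amide-type nitrogen. The expectation is a higher number than for compound 2, a 4.0-fold higher number from compound 2 to compound 3 (0.60 log units; beyond the scatter), with a fair chance that only a limit is reported. Compound 3 is expected to give 8000 nM, between 2500 nM and 30000 nM.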

Compound 3, inhibition constant: > 15800 nM
Compound 3: only a limit was reported (the forecaster's own chance of this, stated with the estimate: 45%); middle value at least 1.9-fold (0.29 log units) from the limit.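

Placing 2,3-dihydro-1H-indol-1-yl on the amide-type nitrogen in place of 4-chlorophenyl gives an at least 7.9-fold higher number from compound 2 to compound 3 (0.89 log units; beyond the scatter) in this assay, so a second group at this place, and the first that is not a substituted phenyl, loses the measurable number that compound 2 holds. Among the compounds shown, 4-chlorophenyl is thus the only group on this nitrogen that gives a number rather than a limit, and a limit now marks both other groups: the limit of > 15800 nM in this assay, at which 2 of the 3 values shown sit. The step between compound 1 and compound 3 cannot be read, since both carry limits, so 2,5-dimethylphenyl and 2,3-dihydro-1H-indol-1-yl cannot be placed in order.

With one number in the series, the compounds shown leave open whether the chlorine, its place on the phenyl ring or the phenyl ring itself matters most, which a 4-fluorophenyl, 4-methylphenyl, 3-chlorophenyl or unsubstituted phenyl group on the same nitrogen would begin to separate. They also leave open whether a group without an aromatic ring, such as cyclohexyl, would give a number at all at this place.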